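Swapping the aryl group on the shared core of compound 1

The source may report more compounds than this note shows. Statements on the series, on what has been measured and on what is new or still open speak of the compounds shown alone.

Compound 1, with the structure `O=C1COc2ccc(-c3[nH]c(-c4ccc(C(F)(F)F)cc4)nc3-c3ccccc3)cc2N1`, was tested in a functional assay on A549 cells (Homo sapiens) for cytotoxicity, read by colorimetric assay and MTT assay, with a stated time of 3 days, tested at 20 uM (on this read-out lower numbers stand for a stronger effect and higher numbers for a weaker effect at the one concentration tested), and gave 21.7%. Compound 2, `O=C1COc2ccc(-c3nn(-c4ccc(Br)cc4)cc3-c3ccccc3)cc2N1`, gives 58.8%, and compound 3, `O=C1COc2ccc(-c3nn(-c4cc(Cl)cc(Cl)c4)cc3-c3ccccc3)cc2N1`, gives 70.2%. Compound 1 therefore stands at the lowest of the three numbers, meaning the strongest effect, with compound 2 nearest and compound 3 furthest away, both gaps beyond the scatter.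

Compound 4, `O=C1COc2ccc(-c3[nH]c(-c4ccc(Cl)cc4Cl)nc3-c3ccccc3)cc2N1`, has not yet been measured. It differs from compound 1 in one place: 2,4-dichlorophenyl in place of 4-(trifluoromethyl)phenyl on an aromatic carbon.

Within the data shown here, only one measured step gives a hint. Replacing a halogenated phenyl by a differently halogenated one on the aromatic nitrogen of compound 2 raised the number by a number 11.4 percentage points higher from compound 2 to compound 3 (beyond the scatter). That step sits on a different ring position and a different core arrangement, so it bears only loosely on the present change, but it suggests that moving halogens around such an aryl group tends to weaken rather than strengthen the effect by a modest amount.

Compound 4 is therefore expected to land somewhat above compound 1, at an estimated 32%, within a range of 12% to 60%, which corresponds to an expected step of a number 10.3 percentage points higher from compound 1 to compound 4 (beyond the scatter).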

Compound 4, a percentage reported as activity, at one concentration (the size of the read-out at that concentration, not a potency): 68.3%
Compound 4: middle estimate off by 36.3 percentage points, on the low side; the whole stated range lies below it.
By their numbers in this assay, from the lowest: compound 1; then compounds 2, 4 and 3 (each within the scatter of the next, the first and the last beyond it).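

In this assay, replacing 4-(trifluoromethyl)phenyl with 2,4-dichlorophenyl on the aromatic carbon between two ring nitrogen atoms gives a number 46.6 percentage points higher from compound 1 to compound 4 (beyond the scatter), so the effect at the one concentration tested depends strongly on which aryl group sits at this place. The leaving and entering groups are alike in several counted features: each has one six-membered aromatic ring of carbon only, neither has a hydrogen-bond donor or acceptor, and neither carries a net charge. These shared counts therefore do not preserve the effect, and a swap between two such halogen-bearing aryl groups can still produce a large step here, but no measurement shown gives a reason for its size.

Going by these compounds, with a single replacement at this place, it remains open whether the weaker effect belongs to the 2,4-dichlorophenyl group as a whole or to one of its two chlorine atoms. On these data alone, it is also open how an unsubstituted phenyl group, or a phenyl ring carrying a methoxy group, an amine or a carboxylic acid, would read at this place on the core of compound 1.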